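Removing a nitro group from benzyl ether anilino cores

The source may report more compounds than this note shows. Statements on the series, on what has been measured and on what is new or still open speak of the compounds shown alone.

Measured compounds:
compound 1 `O=[N+]([O-])c1ccc(COc2ccc(Nc3ncnc4cc5c(cc34)OCCOCCO5)cc2)cc1`, 39700 nM
compound 2 `c1ccc(COc2ccc(Nc3ncnc4cc5c(cc34)OCCOCCO5)cc2)cc1`, > 100000 nM
compound 3 `O=[N+]([O-])c1ccc(COc2cccc(Nc3ncnc4cc5c(cc34)OCCOCCO5)c2)cc1`, 42400 nM

In a functional assay on MCF7 cells (Homo sapiens) for antiproliferative activity, read by MTT assay, with a stated time of 72 h (on this read-out higher numbers stand for weaker inhibition and lower numbers for stronger inhibition), compound 1 gives 39700 nM. Compound 2, which shows (hydrogen in place of nitro on an aromatic carbon), sits at > 100000 nM, a limit of this assay rather than a number; this appears as the limit of > 100000 nM in this assay, at which 1 of the 3 values shown sits. The step of an at least 2.5-fold higher number from compound 1 to compound 2 (0.40 log units; beyond the scatter) is therefore only a lower bound. Compound 3 gives 42400 nM in this assay, within the scatter of compound 1; the difference between the two cores is not broken down here. Compound 4 `c1ccc(COc2cccc(Nc3ncnc4cc5c(cc34)OCCOCCO5)c2)cc1` is not yet measured and shows (hydrogen in place of nitro on an aromatic carbon), the same change. Compound 4 is expected to reach the limit of this assay, estimated as 110000 nM. The step of a 2.6-fold higher number from compound 3 to compound 4 (0.41 log units; beyond the scatter) is expected because of an at least 2.5-fold higher number from compound 1 to compound 2 (0.40 log units; beyond the scatter).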

Compound 4, half-maximal inhibitory concentration: 40900 nM
The estimate for compound 4 lay 2.7-fold (0.43 log units) above the measured number; the whole stated range lies above it.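

In this assay, putting hydrogen in place of the nitro group on the core of compound 3 gives a 1.0-fold lower number from compound 3 to compound 4 (0.02 log units; within the scatter), so on this core the change has no effect that can be told from the usual scatter. Compound 2 sits at > 100000 nM, which is a limit of the assay and not a number. The step on the core of compound 1 is thus only a lower bound, so the change cannot be assumed to carry from one core to the other, yet a true difference between the cores is not shown either: the same change on two cores in this assay, an at least 2.5-fold higher number (0.40 log units; beyond the scatter) from compound 1 to compound 2 and a 1.0-fold lower number (0.02 log units; within the scatter) from compound 3 to compound 4; the limit leaves it open whether they differ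

The compounds shown leave open whether an amine or a carboxylic acid in place of the nitro group would match nitro or hydrogen on either core. They also leave open what a longer chain in place of the benzyl ether link would do.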